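Adding chlorine to a hydroxyphenyl hydrazone: expected potency

This account rests on a few compounds, and the source may have more. Where it says the series, first, only, none or still open, it means among the compounds named here.

Measured so far:
- Compound 1, `O=C(CSc1nnc(-c2ccncc2)o1)N/N=C/c1ccccc1`: 16700 nM
- Compound 2, `O=C(CSc1nnc(-c2ccncc2)o1)N/N=C/c1ccc(Cl)cc1`: 17000 nM
- Compound 3, `O=C(CSc1nnc(-c2ccncc2)o1)N/N=C/c1ccccc1O`: 7380 nM

These three compounds share one core and differ only in the ring that hangs from the carbon doubly bonded to nitrogen. In a functional assay on SW 1116 cells (Homo sapiens) for cytotoxicity, read by MTT assay, with a stated time of 48 h (on this read-out lower numbers stand for stronger inhibition and higher numbers for weaker inhibition), compound 1 gives 16700 nM. Compound 2 carries the change (chloro in place of hydrogen on an aromatic carbon), and the step of a 1.0-fold higher number from compound 1 to compound 2 (0.01 log units; within the scatter) shows that this made no real difference. Compound 3 instead carries the change (hydroxy in place of hydrogen on an aromatic carbon), and the step of a 2.3-fold lower number from compound 1 to compound 3 (0.35 log units; beyond the scatter) is modest but real, as is a 2.3-fold lower number from compound 2 to compound 3 (0.36 log units; beyond the scatter). Compound 3 therefore has the lowest number of the three.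

Compound 4, `O=C(CSc1nnc(-c2ccncc2)o1)N/N=C/c1cc(Cl)ccc1O`, is not yet measured. It differs from compound 3 by chloro in place of hydrogen on an aromatic carbon. Within the data shown here, this is the same kind of change as the one from compound 1 to compound 2, but not the same: there the chlorine sat "para to a large group", here it sits "meta to a large group; para to a hydroxy group". The two cores differ by hydroxy in place of hydrogen on an aromatic carbon.

Because a 1.0-fold higher number from compound 1 to compound 2 (0.01 log units; within the scatter) was within the scatter, the expected step of a 1.0-fold higher number from compound 3 to compound 4 (0.01 log units; within the scatter) is also small. Compound 4 is thus expected to give about 7500 nM in this assay, estimated between 3500 nM and 16000 nM.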

Compound 4, half-maximal inhibitory concentration: 5240 nM
The estimate for compound 4 lay 1.4-fold (0.16 log units) above the measured number, within the range that was stated.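

In this assay, placing the chloro on the core of compound 3 gives a 1.4-fold lower number from compound 3 to compound 4 (0.15 log units; within the scatter), so on both cores the change stays too small to tell from repeat-measurement noise, and the two steps do not differ: the same change on two cores in this assay, a 1.0-fold higher number (0.01 log units; within the scatter) from compound 1 to compound 2 and a 1.4-fold lower number (0.15 log units; within the scatter) from compound 3 to compound 4, 1.4-fold (0.16 log units) apart, within the scatter of two such steps. The larger steps to compound 4 come from swapping the whole ring, which adds the hydroxy as well as changing or adding the chloro: a 3.2-fold lower number from compound 2 to compound 4 (0.51 log units; beyond the scatter), and a 3.2-fold lower number from compound 1 to compound 4 (0.50 log units; beyond the scatter). This shows only that a chloro left the number within the scatter on these two cores, and it does not show that the same would hold on any other core, or separate the effect of the core from that of the chlorine's place, which is para to a large group on the first core but meta to a large group and para to a hydroxy group on the second.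

On these data alone, how the ring responds to a bromo or an amine in place of the chloro in 5-chloro-2-hydroxyphenyl remains open. Also open, as far as these compounds go, is whether a carboxylic acid or a methoxy group in place of the hydroxy would keep the lower numbers seen with compound 3 and compound 4.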